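4-Chlorophenyl in place of the cyclobutadienyloxy chain on the nitro core

The compounds below may be only part of what the source reports. "The series", "measured", "known", "first", "only" and "open" are said of these compounds alone.

Compound 2 `O=C(/C=C/OC1=CC=C1)Nc1nc2ccc([N+](=O)[O-])cc2s1` stands highest of the two numbers in hand. In a functional assay on the whole organism (Hindlimb, strain albino) with Mus musculus as the target, in the maximal electroshock model, with a stated time of 0.5 h (a higher number here means that more compound is needed for the effect, a lower number that less compound is needed), compound 2 gives 597 umol/kg. Compound 1 `O=C(/C=C/c1ccc(Cl)cc1)Nc1nc2ccc(Cl)cc2s1` gives 204 umol/kg, a gap beyond the scatter. For the measured compounds named here, no single-point step between measured compounds exists here. Compound 3 `O=C(/C=C/c1ccc(Cl)cc1)Nc1nc2ccc([N+](=O)[O-])cc2s1` differs from compound 2 in one place: a group of 7 heavy atoms (6 carbon, 1 chlorine; one six-membered aromatic ring of carbon only) in place of a group of 5 heavy atoms (4 carbon, 1 oxygen; one four-membered non-aromatic ring of carbon only), on a double-bonded chain carbon bound to a double-bonded chain carbon. A lower number is expected for compound 3 because the same entering 4-chlorophenyl group is carried by compound 1 at 204 umol/kg. The estimated step of a 2.0-fold lower number from compound 2 to compound 3 (0.30 log units; within the scatter) should fall beyond the scatter. Compound 3 is estimated at 300 umol/kg, within a range from 150 umol/kg to 600 umol/kg.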

Compound 3, dose for half-maximal effect: 259 umol/kg
Beside the measured number, compound 3's estimate is 1.2-fold (0.06 log units) above it, and the stated range covers the measured number.
By their numbers in this assay, from the lowest: compounds 1 and 3 (each within the scatter of the next); then compound 2.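

In this assay, for the compounds shown here, 4-chlorophenyl in place of the group with the four-membered ring, on a double-bonded chain carbon, gives a 2.3-fold lower number from compound 2 to compound 3 (0.36 log units; beyond the scatter) as the first measured step at this position. With 4-chlorophenyl held, nitro in place of chloro on an aromatic carbon gives a 1.3-fold higher number from compound 1 to compound 3 (0.10 log units; within the scatter) and so does not separate the two compounds. No measured evidence bears on the reason for either step.

Open, on these data alone, is whether 4-chlorophenyl matters through its chlorine: a plain phenyl or a 4-methoxyphenyl on the chain would test this. Also open, as far as these compounds go, is how an amine would compare with nitro and chloro on the aromatic carbon.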